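The compounds below may be only part of what the source reports. "The series", "measured", "known", "first", "only" and "open" are said of these compounds alone.

Measured so far:
Compound 1, `N#Cc1ccc(Nc2nc(Oc3ccccc3Cl)c3ccccc3n2)cc1`: 38000 nM
Compound 2, `COc1cc(C#N)cc(Cl)c1Oc1nc(Nc2ccc(C#N)cc2)nc2ccccc12`: 220000 nM
Compound 3, `Cc1cc(C#N)cc(C)c1Oc1nc(Nc2ccc(C#N)cc2)nc2ccc(Cl)cc12`: 117000 nM

These three compounds were tested in an ADME assay on MT4 cells (Homo sapiens) for cytotoxicity, read by MTT assay, with a stated time of 4 days; on this read-out higher numbers stand for lower toxicity in this test and lower numbers for higher toxicity in this test. On this read-out compound 2 has the highest of the three numbers, meaning the lowest toxicity among them. Compound 3 sits closest to it, with a gap that lies within the usual scatter, so the two cannot be told apart with confidence. Compound 1 is furthest away, with a gap that lies beyond the scatter, so compound 2 is clearly less toxic than compound 1 in this assay.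

The next compound, compound 4, `CCCOc1cc(C#N)cc(OC)c1Oc1nc(Nc2ccc(C#N)cc2)nc2ccccc12`, is yet to be measured in this assay. It comes from compound 2 by one change: propoxy in place of chloro on an aromatic carbon

Among the compounds with values here, no pair of measured compounds differs in just one place, so there is no measured step of this kind to lean on. The three measured numbers all lie at high concentrations, and the substituted analogues compound 2 and compound 3 sit close together. The step from compound 2 to compound 4 is therefore expected to be small, a 1.5-fold lower number from compound 2 to compound 4 (0.17 log units; within the scatter), slightly toward higher toxicity, and not clearly beyond the scatter. Compound 4 is estimated to give 150000 nM in this assay, within a range from 50000 nM to 400000 nM.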

Compound 4, half-maximal cytotoxic concentration: 5200 nM
Estimate against measurement, compound 4: 29-fold (1.46 log units) above, outside the stated range (below it).
By their numbers in this assay, from the lowest: compound 4; then compound 1; then compounds 3 and 2 (each within the scatter of the next).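

In this assay, within the data shown here, putting propoxy in place of chloro gives a 42-fold lower number from compound 2 to compound 4 (1.63 log units; beyond the scatter), a large step and the only comparison here between compounds that differ in one place. The earlier numbers could not tie any difference to a single position, whereas this pair shows that a change at this one aromatic carbon, ortho to a large group and meta to both a cyano group and a methoxy group, is enough on its own to move the read-out far toward higher toxicity in this test. Nothing measured here accounts for the size of this step, so it stands as an observation without an explanation.

The swap alters two things at once, the atom attached to the ring and the size of the group, from a single chlorine to a chain of 4 heavy atoms, so this pair cannot show which of the two matters or how the read-out changes with chain length. An ethoxy or butoxy group, or an amine, at this position would help to separate these possibilities, and the same swap on the core of compound 3 would show whether the step carries over to a related compound.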